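Fluorine on the phenyl ring of a dopamine receptor ligand

This account rests on a few compounds, and the source may have more. Where it says the series, first, only, none or still open, it means among the compounds named here.

Measured compounds:
- compound 1 `O/N=C(\CCN1CCN(c2ccccn2)CC1)c1ccccc1`: 4.4 nM
- compound 2 `O/N=C(/CCN1CCN(c2ccccn2)CC1)c1ccccc1`: 21.7 nM
- compound 3 `O/N=C(\CCN1CCN(c2ccccn2)CC1)c1ccccc1Cl`: 24 nM

In a functional assay on HEK293 cells with D(4) dopamine receptor (Homo sapiens) as the target, read by FLIPR (a higher number here means that more compound is needed for the effect, a lower number that less compound is needed), compound 1 gives the lowest number of the three. Compound 2 is its geometric isomer, and the step of a 4.9-fold higher number from compound 1 to compound 2 (0.69 log units; beyond the scatter) rests on the fact that compounds 1 and 2 differ only in the configuration as drawn alone. Compound 3 carries a chloro in place of hydrogen on an aromatic carbon, and the step of a 5.5-fold higher number from compound 1 to compound 3 (0.74 log units; beyond the scatter) is of a similar size.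

Compound 4 `O/N=C(\CCN1CCN(c2ccccn2)CC1)c1cccc(F)c1` has not yet been measured. Compared with compound 1 the change is fluoro in place of hydrogen on an aromatic carbon; it sits meta to a large group, so that phenyl becomes 3-fluorophenyl. Going by the values given here, the only measured step that bears on it is the halogen step to compound 3, which raised the number beyond the scatter. Fluoro is a different halogen at a different place, so that step is a rough guide rather than a template. A modest rise is therefore expected, smaller than the one seen with chloro: the step from compound 1 to compound 4 is estimated at a 2.0-fold higher number from compound 1 to compound 4 (0.31 log units; beyond the scatter) in this assay. For compound 4 the expected value in this assay is 9 nM, with a range from 3 nM to 27 nM.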

Compound 4, half-maximal effective concentration: 17.1 nM
Estimate against measurement, compound 4: 1.9-fold (0.28 log units) below; low and high end bracket the measured number.
By their numbers in this assay, from the lowest: compound 1; then compounds 4, 2 and 3 (each within the scatter of the next).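

A single fluoro on the phenyl ring is enough to shift the number in this assay (a 3.9-fold higher number from compound 1 to compound 4 (0.59 log units; beyond the scatter)), so a rise beyond the scatter is no longer tied to chloro alone. The two halogen-bearing compounds also land close together (a 1.4-fold lower number from compound 3 to compound 4 (0.15 log units; within the scatter)), a gap within the scatter, even though both the halogen and its place on the ring differ between them. Compound 1, with its plain phenyl, now has the lowest number of the four, and each of the three single changes shown around it, the double-bond geometry included, gives a higher number beyond the scatter.

The compounds shown leave open whether the halogen or its place on the ring matters more, since compounds 3 and 4 change both at once, and whether a methyl or a methoxy group on the same ring would also raise the number or whether this is particular to halogens. The data given here offer no explanation for the rise seen with fluoro.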